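The compounds below may be only part of what the source reports. "The series", "measured", "known", "first", "only" and "open" are said of these compounds alone.

Measured so far:
- compound 1, `COc1cc(-c2nnc(SCC(=O)Nc3ccc(/C(C)=N/O)cc3)n2-c2ccccc2)cc(OC)c1OC`: 62%
- compound 2, `C=CCn1c(SCC(=O)Nc2ccc(/C(C)=N/O)cc2)nnc1-c1ccccc1`: 63%
- compound 3, `C/C(=N\O)c1ccc(NC(=O)CSc2nnc(-c3ccccc3)n2-c2ccccc2)cc1`: 52%

In a functional assay on the whole organism (strain albino) for inhibition, with Rattus norvegicus as the target, read by paw edema, with stated times of 30 min and 2 h, at a dose of 0.28 mmol/kg by the oral route (a higher number here means more inhibition at the dose given (going by the name of the read-out), a lower number less inhibition), compound 3 gives 52%, the lowest of the three numbers. Its nearest neighbour is compound 1, and the step of a number 10 percentage points lower from compound 1 to compound 3 (within the scatter) lies within the scatter, so no order between these two can be read. The step of a number 11 percentage points lower from compound 2 to compound 3 (beyond the scatter) is modest but beyond the scatter.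

Compound 4, `COc1ccc(-c2nnc(SCC(=O)Nc3ccc(/C(C)=N/O)cc3)n2-c2ccccc2)cc1`, has not yet been measured. It differs from compound 3 by methoxy in place of hydrogen on an aromatic carbon; cut one bond further out, the difference reads phenyl to 4-methoxyphenyl. Among the compounds with values here, the only measured step that bears on it is the exchange at the same ring between compound 1 and compound 3, where a number 10 percentage points lower from compound 1 to compound 3 (within the scatter) was within the scatter. A single methoxy is a smaller change than the three of compound 1, so the estimated step of a number 5 percentage points higher from compound 3 to compound 4 (within the scatter) is expected to be small, if anything slightly upward, and not clearly beyond the scatter. The estimate for compound 4 is therefore 57%, expected to fall between 47% and 67%.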

Compound 4, a percentage reported as inhibition, in the whole organism at one dose (the size of the read-out at that dose, not a potency): 56%
The estimate for compound 4 lay 1 percentage points above the measured number; the measured number falls inside the stated range.
By their numbers in this assay, from the lowest: compounds 3, 4, 1 and 2 (each within the scatter of the next, the first and the last beyond it).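

In this assay a single methoxy on the aromatic carbon para to a large group stays within the scatter of plain phenyl (a number 4 percentage points higher from compound 3 to compound 4 (within the scatter)), so this position takes that group without a readable change. The exchange for the 3,4,5-trimethoxyphenyl of compound 1 also stays within the scatter (a number 6 percentage points lower from compound 1 to compound 4 (within the scatter)), which fills in the middle of the earlier pair: phenyl, 4-methoxyphenyl and 3,4,5-trimethoxyphenyl show no order that can be read here. Nothing available explains these numbers, and no cause can be offered for them.

The compounds shown leave open whether an amine or a carboxylic acid on this same carbon would give a step beyond the scatter. They also leave open whether 4-methoxyphenyl would behave alike with allyl on the aromatic nitrogen, as in compound 2.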